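Thienopyridine ureas: ring-nitrogen substituent and zebrafish potency

This account rests on a few compounds, and the source may have more. Where it says the series, first, only, none or still open, it means among the compounds named here.

Measured compounds:
compound 1 `CC(C)(C)OC(=O)CCCN1CCc2c(sc(NC(=O)Nc3ccc(Cl)cc3)c2C(N)=O)C1`, 560 nM
compound 2 `CCN1CCc2c(sc(NC(=O)Nc3ccc(Br)cc3)c2C(N)=O)C1`, 3130 nM
compound 3 `CC(C)(C)OC(=O)CN1CCc2c(sc(NC(=O)Nc3ccc(Cl)cc3)c2C(N)=O)C1`, > 25000 nM

Compound 1 gives 560 nM in a functional assay (strain AB) with Danio rerio as the target, read by microscopy, with a stated time of 1 h; a lower number here means that less compound is needed, a higher number that more compound is needed for the effect. Compound 2, which carries ethyl at the ring amine nitrogen, gives 3130 nM. For compound 3 only a limit is recorded: > 25000 nM, and so compound 3 stands at the weak end of the numbers seen so far, with no exact value. This limit is the limit of > 25000 nM in this assay, at which 1 of the 3 values shown sits.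

Within the data shown here, the one measured step that touches this part of the molecule is an at least 44-fold higher number from compound 1 to compound 3 (1.64 log units; beyond the scatter). It shows that shortening the chain that carries the tert-butoxycarbonyl group at this nitrogen moves the number far upward.

The step under study is compound 3 to compound 4 `CCN1CCc2c(sc(NC(=O)Nc3ccc(Cl)cc3)c2C(N)=O)C1`: methyl in place of tert-butoxycarbonyl on a saturated chain carbon bound to an amine nitrogen in a ring. Among the measured compounds shown here, no measured step covers exactly this change. Compound 2, however, bears the same ethyl group on the same nitrogen and sits at 3130 nM, well within the measurable range. Compound 3, by contrast, is recorded only as a limit. On that basis the number for compound 4 is expected to come down markedly, a step of about an at least 8.3-fold lower number from compound 3 to compound 4 (0.92 log units; beyond the scatter). The estimate for compound 4 in this assay is 3000 nM, within a range of 1000 nM to 10000 nM.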

Compound 4, half-maximal effective concentration: 3120 nM
The estimate for compound 4 lay 1.0-fold (0.02 log units) below the measured number, and the stated range covers the measured number.
By their numbers in this assay, from the lowest: compound 1; then compounds 4 and 2 (each within the scatter of the next). At a limit, above all of these: compound 3.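

Exchanging bromo for chloro on an aromatic carbon does not register in this assay, a 1.0-fold lower number from compound 2 to compound 4 (0.00 log units; within the scatter), so the ethyl compounds can be read as one point and compound 4 becomes the reference for the ring-nitrogen substituent. Against that reference the two compounds bearing tert-butoxycarbonyl fall on opposite sides, with a 5.6-fold higher number from compound 1 to compound 4 (0.75 log units; beyond the scatter) and an at least 8.0-fold lower number from compound 3 to compound 4 (0.90 log units; beyond the scatter), so the presence of this group does not by itself set the direction of the change, and its distance from the ring amine nitrogen matters within these three compounds. Compound 3 is recorded only as a limit, so its step to compound 4 gives a minimum size and not a measured one: the limit of > 25000 nM in this assay, at which 1 of the 4 values shown sits.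

From the compounds shown here alone, whether the advantage of compound 1 over compound 4 comes from the tert-butoxycarbonyl group or from the longer chain alone remains open, and a plain longer alkyl chain, or the same chain ending in a carboxylic acid or an amine, would separate the two. The equivalence of chloro and bromo is also shown only for the ethyl compounds, and it remains open whether it holds with the longer chain of compound 1.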